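The source may report more compounds than this note shows. Statements on the series, on what has been measured and on what is new or still open speak of the compounds shown alone.

Measured so far:
- compound 1, `CCC(CC)=NNc1nc(-c2cccc([N+](=O)[O-])c2)cs1`: 1130000 nM
- compound 2, `C/C(CC(C)C)=N/Nc1nc(-c2cccc([N+](=O)[O-])c2)cs1`: 1350000 nM
- compound 3, `CCC/C(CC)=N\Nc1nc(-c2cccc([N+](=O)[O-])c2)cs1`: 1230000 nM

All three compounds share the same core and differ only in the branched chain hanging from the nitrogen on the aromatic ring. In a functional assay, with a stated time of 30 min (a higher number here means a weaker inhibitor, a lower number a stronger inhibitor), compound 1 gives 1130000 nM, and the step of a 1.2-fold higher number from compound 1 to compound 2 (0.08 log units; within the scatter) and the step of a 1.1-fold lower number from compound 2 to compound 3 (0.04 log units; within the scatter) are both small. Compound 2 therefore sits among the others rather than apart from them: every step to it lies within the scatter, so no ranking among the three can be read from these numbers.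

Compound 4, `CCCCCC/C(C)=N\Nc1nc(-c2cccc([N+](=O)[O-])c2)cs1`, is the next compound. Its change from compound 2 is pentyl in place of isopropyl on a saturated chain carbon bound to a carbon with a double bond to nitrogen, a straight chain of five carbons in place of a branched one of three. Within the data shown here, none of the measured steps alters this chain in the same way; the nearest comparisons are a 1.2-fold higher number from compound 1 to compound 2 (0.08 log units; within the scatter), a 1.1-fold higher number from compound 1 to compound 3 (0.04 log units; within the scatter) and a 1.1-fold lower number from compound 2 to compound 3 (0.04 log units; within the scatter), all changes of shape or size in the same chain, and all within the scatter.

On that basis no step beyond the scatter is expected for compound 4 in this assay: the expected step is a 1.0-fold lower number from compound 2 to compound 4 (0.02 log units; within the scatter). The estimate for compound 4 is 1300000 nM, with a range from 500000 nM to 3500000 nM.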

Compound 4, half-maximal inhibitory concentration: 1150000 nM
Estimate against measurement, compound 4: 1.1-fold (0.05 log units) above, within the range that was stated.
By their numbers in this assay, from the lowest: compounds 1, 4, 3 and 2 (each within the scatter of the next).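

The earlier compounds shown here varied the chain only modestly, whereas here isopropyl gives way to pentyl, a straight chain in place of a branched one, on a saturated chain carbon bound to a carbon with a double bond to nitrogen. In this assay, this swap gives a 1.2-fold lower number from compound 2 to compound 4 (0.07 log units; within the scatter), so neither the added length nor the loss of the branch produces a difference that can be read from these numbers, and a straight chain and a branched one cannot be told apart at this place. Nothing shown here offers an explanation for this result.

All the chains shown are built from carbon alone, so it remains open whether an amine, a hydroxyl or a carboxylic acid at this place would give a step beyond the scatter. As far as these compounds go, it is equally open whether a chain much longer than pentyl would still leave the number where it is, or whether a change elsewhere on the shared core would matter more than any change to this chain.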